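Replacing the pyrazolyl amide substituent with phenyl

The source may hold more compounds than are shown below. What is called first, only, known or untested is meant among the compounds shown, and "the series" means these compounds.

Three aryloxyacetamides have been measured in an assay on HEK293 cells for agonist activity at transient receptor potential cation channel subfamily M member 8 (Homo sapiens), read by fluorescence and calcium flux, with a stated time of 15 min; on this read-out higher numbers stand for an effect only at larger amounts of compound and lower numbers for an effect already at smaller amounts. Compound 1 `Cc1ccc(OCC(=O)N(Cc2cccs2)c2ccn(C)n2)cc1` gives 855 nM in this assay. Compound 2 `CCN(Cc1ccoc1)C(=O)COc1ccc(C)cc1` gives 136 nM, and compound 3 `CCN(Cc1cccs1)C(=O)COc1ccccc1` gives 1400 nM. Among these three numbers compound 1 holds the second highest place: its value and that of compound 3 lie within the scatter of each other, so no order between them can be read, whereas compound 2 stands at a lower number and beyond the scatter from compound 1. No pair of these compounds differs in one place only, so no single-point step has been measured within the set.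

Compound 4 `Cc1ccc(OCC(=O)N(Cc2cccs2)c2ccccc2)cc1` has not yet been measured. Relative to compound 1 the change is phenyl in place of 1-methyl-1H-pyrazol-3-yl on an amide-type nitrogen. The substituent on the amide-type nitrogen is thus exchanged while the rest of the core is kept. Among the measured compounds shown here, nothing among the measured compounds isolates the effect of the group on the amide-type nitrogen, so the expectation rests on the general range of the set. A modest shift toward a lower number is expected for compound 4, with the step from compound 1 estimated as a 1.7-fold lower number from compound 1 to compound 4 (0.23 log units; within the scatter). Compound 4 is estimated at 500 nM in this assay, within a range from 150 nM to 2000 nM.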

Compound 4, half-maximal effective concentration: 23 nM
The estimate for compound 4 lay 22-fold (1.34 log units) above the measured number; the whole stated range lies above it.
By their numbers in this assay, from the lowest: compound 4; then compound 2; then compounds 1 and 3 (each within the scatter of the next).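

Within this assay, the group on the amide-type nitrogen proves able to move the number strongly, and the series now has its first single-place step: phenyl in place of 1-methyl-1H-pyrazol-3-yl gives a 37-fold lower number from compound 1 to compound 4 (1.57 log units; beyond the scatter) with the rest of the core kept. The count of 6 heavy atoms stays the same, while a five-membered aromatic ring with 2 hetero atoms and 2 hydrogen-bond acceptors gives way to a six-membered aromatic ring of carbon only with 0 hydrogen-bond acceptors, so ring size, ring atoms and acceptor count all change in this one step. No measurement shown here bears on the reason for the step.

A single step cannot separate these changes from one another, and a pyridyl ring at the same place, or a phenyl ring carrying a methoxy group or a carboxylic acid, would be needed to tell how far the phenyl result extends. Going by these compounds, it also remains open whether the same exchange has a step of similar size when ethyl, rather than the thiophen-containing chain of compound 4, is the other substituent on the amide-type nitrogen.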